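The source may report more compounds than this note shows. Statements on the series, on what has been measured and on what is new or still open speak of the compounds shown alone.

Measured compounds:
compound 1 `COC(=O)c1sc2cc(-c3cnn(C)c3)cnc2c1N` — > 150000 nM
compound 2 `COC(=O)c1sc2cc(-c3ccc(OC)cc3)cnc2c1N` — > 150000 nM

In a functional assay on A-375 cells (Homo sapiens) for inhibition, read by sulforhodamine B assay, with a stated time of 48 h (on this read-out higher numbers stand for weaker inhibition of growth and lower numbers for stronger inhibition of growth), compound 1 gives only a limit, > 150000 nM. In this assay compound 2 likewise gives only a limit, > 150000 nM. Compound 2 thus stands at the limit of > 150000 nM in this assay, at which 2 of the 2 values shown sit, and no number separates it from compound 1.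

Compound 3 `COC(=O)c1sc2cc(-c3ccc(N)cc3)cnc2c1N` is not yet measured. It differs from compound 2 by amino in place of methoxy on an aromatic carbon. Among the compounds with values here, no measured step of this kind exists, so no direction can be read from it. Because compound 2 gives only the limit > 150000 nM in this assay, the step that the limit leaves unreadable from compound 2 to compound 3 is expected to be none beyond the scatter. Compound 3 is therefore expected at 200000 nM, within 60000 nM to 600000 nM, most probably reported again as a limit.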

Compound 3, concentration for 50% growth inhibition: 80800 nM
Compound 3: middle estimate off by 2.5-fold (0.39 log units), on the high side, within the range that was stated.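

Within the data shown here, compound 3, at 80800 nM in this assay, is the first compound to give a number rather than a limit, so changes at this place on the six-membered aromatic ring can be read. Amino in place of methoxy gives an at least 1.8-fold lower number from compound 2 to compound 3 (0.26 log units; that floor lies within the scatter), and 4-aminophenyl in place of 1-methyl-1H-pyrazol-4-yl gives an at least 1.8-fold lower number from compound 1 to compound 3 (0.26 log units; that floor lies within the scatter). Both steps are floors, not full sizes, because their starting compounds stand at a limit: the limit of > 150000 nM in this assay, at which 2 of the 3 values shown sit.

The compounds shown leave open how a hydroxyl, dimethylamino or acetamido group would read at this place. They also leave open how far the true size of either step exceeds its floor.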